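Positive allosteric modulation by three aryl ketone acids

A few compounds are considered here, and "the series" means these few. Any claim that something is new, unique, unknown or untested is made for them only; others in the source may bear on it.

Measured compounds:
compound 1, `CCC(=O)c1ccc(OCCCCOc2cc(C(=O)O)ccc2OC)c(C)c1O`, 62.5%;
compound 2, `COc1ccc(C(=O)O)cc1OCCCCOc1ccc(C(=O)C(C)C)c(O)c1C`, 59.9%;
compound 3, `COc1cc(C(=O)O)ccc1OCCCCOc1ccc(C(C)=O)c(O)c1C`, 26.3%.

In an assay on HEK293 cells for positive allosteric modulation of metabotropic glutamate receptor 3 (Rattus norvegicus), read by thallium flux, with a stated time of 2.5 min (a lower number here means a smaller maximal response, a higher number a larger maximal response), compound 1 and compound 2 sit close together, and the step of a number 2.6 percentage points lower from compound 1 to compound 2 (within the scatter) comes from methyl in place of hydrogen on a saturated chain carbon bound to a carbonyl carbon and a saturated chain carbon. Compound 3 stands lowest of the three, and the difference between its core and the core of compound 1 is not broken down here. Compound 4, `CCC(=O)c1ccc(OCCCCOc2ccc(C(=O)O)cc2OC)c(C)c1O`, has not been measured; it differs from compound 3 by methyl in place of hydrogen on a saturated chain carbon bound to a carbonyl carbon. This is the same kind of change as from compound 1 to compound 2, though the place differs: there the carbon was bound to a carbonyl carbon and a saturated chain carbon, here only to a carbonyl carbon. Because a number 2.6 percentage points lower from compound 1 to compound 2 (within the scatter) stayed within the scatter, a step of similar size, a number 6.7 percentage points higher from compound 3 to compound 4 (within the scatter), is expected for compound 4. Compound 4 is therefore estimated at 33%, between 15% and 58%.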

Compound 4, largest response reached (reported as percent of maximum), in percent of the reference or control that the assay uses: 25.9%
Beside the measured number, compound 4's estimate is 7.1 percentage points above it; low and high end bracket the measured number.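

In this assay, the new step, a number 0.4 percentage points lower from compound 3 to compound 4 (within the scatter), comes from methyl in place of hydrogen on a saturated chain carbon bound to a carbonyl carbon. Set beside the earlier step, this change behaves alike on the two cores: the same change on two cores in this assay, a number 2.6 percentage points lower (within the scatter) from compound 1 to compound 2 and a number 0.4 percentage points lower (within the scatter) from compound 3 to compound 4, 2.2 percentage points apart, within the scatter of two such steps. Going by these compounds alone, this shows only that the change leaves the maximal response unmoved on these two cores; it does not show that a larger step could not appear on another core, and neither step says what sets the level of the response.

The compounds shown leave open how an acyl chain longer than propanoyl would read in this assay. They also leave open what an amide in place of the carboxylic acid would give.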